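Swapping the methoxyphenyl arm of a fatty acid receptor agonist

A few compounds are considered here, and "the series" means these few. Any claim that something is new, unique, unknown or untested is made for them only; others in the source may bear on it.

Measured so far:
compound 1 `CC#CC(CC(=O)O)c1ccc(OCc2ccc3nc(-c4ccc(OC)cc4)cn3c2)cc1`: 47 nM
compound 2 `CC#CC(CC(=O)O)c1ccc(OCc2ccn3cc(-c4ccc(CC)cc4)nc3c2)cc1`: 671 nM
compound 3 `CC#CC(CC(=O)O)c1ccc(OCc2ccn3cc(-c4ccccc4C)nc3c2)cc1`: 459 nM

In an assay on isolated protein for agonist activity at Free fatty acid receptor 1 (Homo sapiens) (a lower number here means that less compound is needed, a higher number that more compound is needed for the effect), compound 1 gives the lowest of the three numbers; compound 3 sits nearest and compound 2 furthest, both beyond the scatter. Compound 4 `CC#CC(CC(=O)O)c1ccc(OCc2ccc3nc(-c4cccc(C)c4)cn3c2)cc1` differs from compound 1 by 3-methylphenyl in place of 4-methoxyphenyl on an aromatic carbon. Going by the values given here, the only measured step at that pendant ring is a 1.5-fold lower number from compound 2 to compound 3 (0.16 log units; within the scatter), made on the core of compound 2 rather than that of compound 1, and it changes little. Among the compounds with values here, no measured pair removes the methoxy acceptor. A modest rise in this assay is therefore expected for compound 4, a 2.1-fold higher number from compound 1 to compound 4 (0.33 log units; beyond the scatter), with an estimated 100 nM in a range from 35 nM to 300 nM.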

Compound 4, half-maximal effective concentration: 1050 nM
Estimate against measurement, compound 4: 11-fold (1.02 log units) below; the whole stated range lies below it.
By their numbers in this assay, from the lowest: compound 1; then compounds 3, 2 and 4 (each within the scatter of the next, the first and the last beyond it).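

In this assay, going by these compounds alone, the pendant ring on the core of compound 1 proves sensitive: 3-methylphenyl in place of 4-methoxyphenyl gives a 22-fold higher number from compound 1 to compound 4 (1.35 log units; beyond the scatter), a large step, whereas the only earlier step at that ring was a 1.5-fold lower number from compound 2 to compound 3 (0.16 log units; within the scatter). The change removes the hydrogen-bond acceptor of 4-methoxyphenyl and also moves the substituent on the ring, and this one step cannot separate the two. Nothing available explains the size of the step.

Which of the two differences carries the loss remains open. So does how a hydroxyl or an amine on that ring would behave on this core.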